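Dropping a methyl: what a related pair predicts

A few compounds are considered here, and "the series" means these few. Any claim that something is new, unique, unknown or untested is made for them only; others in the source may bear on it.

In a functional assay on T47D cells (Homo sapiens) for cytotoxicity, with a stated time of 72 h, tested at 50 ug/mL (a lower number here means a weaker effect, a higher number a stronger effect of the compound at the concentration tested), three compounds have been measured:
compound 1 `Cc1ccc(N2CCN/C2=N\N)cc1` gives 17%;
compound 2 `Cc1ccc(N2CCn3c2n[nH]c(=O)c3=N)cc1` gives 0%;
compound 3 `N/N=C1\NCCN1c1ccccc1` gives 0%.

Compound 3 differs from compound 1 by hydrogen in place of methyl on an aromatic carbon, and this gave a number 17 percentage points lower from compound 1 to compound 3 (beyond the scatter). Compound 2 and compound 1 have different cores; how they differ is not broken down here. Compound 4 `N=c1c(=O)[nH]nc2n1CCN2c1ccccc1` stands to compound 2 as compound 3 stands to compound 1, by hydrogen in place of methyl on an aromatic carbon. The surroundings are described differently, as para to a large group rather than para to a group of 7 heavy atoms, so this is the same kind of change, not the same. Compound 2 already sits at the bottom with compound 3, so the step is expected to be about no change at the digits printed from compound 2 to compound 4 (within the scatter). Compound 4 is therefore estimated at 0%, between 0% and 10%.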

Compound 4, a percentage reported as inhibition, at one concentration (the size of the read-out at that concentration, not a potency): 3%
The estimate for compound 4 lay 3 percentage points below the measured number; low and high end bracket the measured number.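

Replacing the methyl with hydrogen on the second core gives a number 3 percentage points higher from compound 2 to compound 4 (within the scatter) in this assay. The change therefore does not carry over as one fixed step between these two cores: the same change on two cores in this assay, a number 17 percentage points lower (beyond the scatter) from compound 1 to compound 3 and a number 3 percentage points higher (within the scatter) from compound 2 to compound 4, 20 percentage points apart, beyond the scatter of two such steps. This does not show that the methyl has no effect on the core of compound 2, as compound 2 already gives 0% and so leaves little room for a further drop to be seen.

The compounds shown leave open how the core of compound 1 would respond to other groups in the same place, such as a chlorine atom, a methoxy group or a longer chain. For the compounds shown here, with only one pair on each core, it also remains open whether either step is typical of its core.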